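Chloro to trifluoromethyl on the phenoxy ring of compound 2

This account rests on a few compounds, and the source may have more. Where it says the series, first, only, none or still open, it means among the compounds named here.

Measured compounds:
compound 2 `Cc1cn(C2CCN(Cc3cccc(Oc4cccc(Cl)c4)c3)CC2)c(=O)[nH]c1=O`: 21000 nM
compound 1 `Cc1cn(C2CCN(Cc3cccc(Oc4cc(C(F)(F)F)cc(C(F)(F)F)c4)c3)CC2)c(=O)[nH]c1=O`: "not determined" (no result reported)

Among the measured compounds shown here, compound 2 is the only compound here with a number in an ADME assay on MRC5 cells (Homo sapiens) for cytotoxicity, read by fluorescence and resazurin assay, with a stated time of 3 days; on this read-out lower numbers stand for stronger inhibition and higher numbers for weaker inhibition; in this assay compound 1 `Cc1cn(C2CCN(Cc3cccc(Oc4cc(C(F)(F)F)cc(C(F)(F)F)c4)c3)CC2)c(=O)[nH]c1=O` gives "not determined" (no result reported), so nothing can be said of how the two compare. In this assay compound 2 gives 21000 nM, and that single value is the whole reference point for what follows.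

Compound 3 `Cc1cn(C2CCN(Cc3cccc(Oc4cccc(C(F)(F)F)c4)c3)CC2)c(=O)[nH]c1=O` differs from compound 2 in one place: trifluoromethyl in place of chloro on an aromatic carbon. No pair of measured compounds shows the effect of this exchange, so there is no shown step to lean on. Given that compound 2 gives 21000 nM and that the change is a single group on one aromatic carbon, the expected step from compound 2 to compound 3 is small, with a 1.2-fold lower number from compound 2 to compound 3 (0.07 log units; within the scatter) expected to stay within the usual scatter in either direction. Compound 3 is therefore estimated at 18000 nM, with a range from 8000 nM to 45000 nM.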

Compound 3, half-maximal inhibitory concentration: 12400 nM
Compound 3: the middle estimate sits 1.5-fold (0.16 log units) above what was measured, within the range that was stated.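

In this assay, among the compounds shown here, the exchange of chloro for trifluoromethyl on the phenoxy ring gives a 1.7-fold lower number from compound 2 to compound 3 (0.23 log units; within the scatter), the first step that can be read at this place on the aromatic ring. It shows that going from 3-chlorophenoxy to 3-(trifluoromethyl)phenoxy, with 1 heavy atom leaving and 4 heavy atoms entering, does not move the read-out beyond the usual scatter, so compound 2 and compound 3 cannot be told apart on this evidence. Nothing shown here gives a reason for this outcome, and no measurement of any property of these two groups accompanies it.

The compounds shown leave open whether this place stays as insensitive with a different kind of group, such as a nitrile, a methoxy group, an amine or a carboxylic acid, since chloro and trifluoromethyl are the only two groups with numbers here. They also leave open what a second trifluoromethyl on the ring does, since compound 1 carries one but has no number to set beside that of compound 3.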